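A few compounds are considered here, and "the series" means these few. Any claim that something is new, unique, unknown or untested is made for them only; others in the source may bear on it.

Compound 1 `COc1cc(-c2nnc3n2NC(c2cccs2)C(C(=O)c2ccccc2)S3)cc(OC)c1OC` is one of three closely related compounds that share the same core and differ only in the aryl group attached to the carbonyl carbon. In a functional assay on PC-3 cells (Homo sapiens) for cytotoxicity, read by MTT assay, with a stated time of 48 h (a lower number here means a stronger inhibitor, a higher number a weaker inhibitor), compound 1 gives 86300 nM, the higher of the two numbers measured outright. Compound 2 `COc1cc(-c2nnc3n2NC(c2ccco2)C(C(=O)c2ccc(F)c(F)c2)S3)cc(OC)c1OC` gives 36000 nM in this assay, a lower number that lies beyond the scatter of the measurement. For compound 3 `COc1cc(-c2nnc3n2NC(c2ccco2)C(C(=O)c2ccccc2F)S3)cc(OC)c1OC` this assay reports only a limit, > 100000 nM, so no number is known for it. Among the measured compounds shown here, the one step measured between single changes, an at least 2.7-fold higher number from compound 2 to compound 3 (0.44 log units; beyond the scatter), moves the number upward, and its size is only known as a lower bound because of the limit of > 100000 nM in this assay, at which 1 of the 3 values shown sits.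

Compound 4 `COc1cc(-c2nnc3n2NC(c2cccs2)C(C(=O)c2ccc(Cl)cc2)S3)cc(OC)c1OC` differs from compound 1 by chloro in place of hydrogen on an aromatic carbon. For the measured compounds named here, the only measured step, from compound 2 to compound 3, also changes a halogen pattern on the ring attached to the carbonyl carbon, and there the number rose at least modestly; no measured step introduces a chloro group. On this thin evidence, the expected change in this assay from compound 1 to compound 4 is small, within or just beyond the scatter, with no clear direction. The estimate for compound 4 in this assay is 70000 nM, with a range from 25000 nM to 150000 nM, which amounts to an expected step of a 1.2-fold lower number from compound 1 to compound 4 (0.09 log units; within the scatter).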

Compound 4, half-maximal inhibitory concentration: 32500 nM
Compound 4: the middle estimate sits 2.2-fold (0.33 log units) above what was measured; the range from low to high includes it.
By their numbers in this assay, from the lowest: compounds 4 and 2 (each within the scatter of the next); then compound 1. At a limit, above all of these: compound 3.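

Turning the phenyl on the carbonyl into 4-chlorophenyl gives a 2.7-fold lower number from compound 1 to compound 4 (0.42 log units; beyond the scatter) in this assay and this is the first measured single change on this ring that lowers the number. The earlier step of an at least 2.7-fold higher number from compound 2 to compound 3 (0.44 log units; beyond the scatter) went the other way, so across these compounds, halogen changes on this ring do not all move the number in one direction. Nothing shown here explains why adding chloro at this place lowers the number.

On these data alone, it remains open whether the drop is particular to chloro or would also appear with a different group at the same place on the ring, such as a methoxy group, an amine or a carboxylic acid. As far as these compounds go, it also remains open whether chloro would give a similar step in the background of compound 2, which differs from compound 1 in a second place as well as on this ring.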